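Aryl variation on the ring nitrogen: toward compound 4

The source may report more compounds than this note shows. Statements on the series, on what has been measured and on what is new or still open speak of the compounds shown alone.

Measured so far in an assay on isolated protein for inhibition of protein kinase C zeta type (Homo sapiens), with a stated time of 4 min, tested at 62.5 uM; a higher number here means more inhibition at the concentration tested (going by the name of the read-out), a lower number less inhibition:
compound 1 `Cc1cccc(N2N=C(C(C)(C)C)CC2c2ccc(O)cc2)c1`: 91.7%
compound 2 `CC(C)(C)C1=NN(c2ccc(F)cc2F)C(c2ccc(O)cc2)C1`: 68%
compound 3 `Cc1ccc(N2N=C(C(C)(C)C)CC2c2ccc(O)cc2)c(C)c1`: 59.9%

Compound 3 has the lowest number of the three; its gap to compound 2 is within the scatter, while a number 31.8 percentage points lower from compound 1 to compound 3 (beyond the scatter) is beyond it, as is a number 23.7 percentage points lower from compound 1 to compound 2 (beyond the scatter). The step of a number 8.1 percentage points lower from compound 2 to compound 3 (within the scatter) therefore separates little.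

Compound 4 `CC(C)(C)C1=NN(c2ccc(O)cc2)C(c2ccc(O)cc2)C1` carries the change (4-hydroxyphenyl in place of 2,4-dimethylphenyl on an amine nitrogen in a ring). Among the measured compounds shown here, no measured step introduces a 4-hydroxyphenyl on an amine nitrogen in a ring, so the two steps from compound 1 show only that exchanging this aryl group can move this assay modestly to largely. The expectation for compound 4 is a small rise, near a number 8.1 percentage points higher from compound 3 to compound 4 (within the scatter), not certain to exceed the scatter. Compound 4 is estimated at 68%, between 45% and 90%.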

Compound 4, a percentage reported as inhibition, at one concentration (the size of the read-out at that concentration, not a potency): 40.9%
Beside the measured number, compound 4's estimate is 27.1 percentage points above it, outside the stated range (below it).
By their numbers in this assay, from the lowest: compound 4; then compounds 3 and 2 (each within the scatter of the next); then compound 1.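

In this assay the 4-hydroxyphenyl group on the ring nitrogen gives the lowest number of the aryl groups shown, with a number 19 percentage points lower from compound 3 to compound 4 (beyond the scatter) and a number 27.1 percentage points lower from compound 2 to compound 4 (beyond the scatter) and a number 50.8 percentage points lower from compound 1 to compound 4 (beyond the scatter) as its steps. Compound 4 thus falls below compound 2 and compound 3, which stay within the scatter of each other, so this position separates more than 3-methylphenyl from the rest. Nothing given here explains the fall.

Open, from the compounds shown here alone, is whether the hydroxyl itself or its place on the aryl ring sets this level. A 4-methoxyphenyl, 3-hydroxyphenyl or 4-aminophenyl group at this position would help separate those readings.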